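This account rests on a few compounds, and the source may have more. Where it says the series, first, only, none or still open, it means among the compounds named here.

Three compounds have been examined in a functional assay on VCaP cells (Homo sapiens) for antiproliferative activity, read by CCK-8 assay, with a stated time of 6 days; a lower number here means a stronger inhibitor, a higher number a weaker inhibitor. For compound 1 (`N#Cc1ccc(N2CCc3cc(-c4cnc5ccccc5c4)ccc32)cc1C(F)(F)F`) the entry reads "not determined" (no result reported) and offers nothing to compare. Compound 3 (`Cn1nccc1-c1cccc2c1CCCN2c1ccc(C#N)c(C(F)(F)F)c1`) gives > 30000 nM as its result, which is a limit of the assay and not a number. Going by the values given here, that leaves compound 2 (`CCN(c1ccc(C#N)c(Cl)c1)c1cc(-n2cnc3ccccc32)ccc1C`), at 8560 nM in this assay, as the only actual number in the set, so it cannot be ranked against a second value and serves as the sole reference point.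

Compound 4 (`CCN(c1ccc(C#N)c(Cl)c1)c1cc(-c2ccccc2)ccc1C`) keeps everything in compound 2 except one group, as phenyl in place of 1H-benzimidazol-1-yl on an aromatic carbon sets out. Compound 2 carries 1H-benzimidazol-1-yl there, and compound 4 carries phenyl. Among the compounds with values here, no two measured compounds differ in just one place, so the data offer no direct precedent for this swap. The best available anchor is therefore compound 2 at 8560 nM itself, and no step beyond the scatter is expected in this assay, in either direction. The expected change is a 1.2-fold higher number from compound 2 to compound 4 (0.07 log units; within the scatter) and it remains an estimate. For compound 4 the estimated value is 10000 nM and the wide expected range runs from 3000 nM to 30000 nM to reflect how little guidance exists.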

Compound 4, half-maximal inhibitory concentration: > 30000 nM
Compound 4 was reported as a limit; the forecaster's own chance of this, stated with the estimate: 15%; middle value at least 3.0-fold (0.47 log units) away from the limit.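

Going by these compounds alone, replacing 1H-benzimidazol-1-yl with phenyl on this aromatic carbon, meta to a large group and para to a methyl group, provides the first comparison of compounds that differ in only one place. In this assay, the change gives an at least 3.5-fold higher number from compound 2 to compound 4 (0.54 log units; beyond the scatter), so the group at this position clearly affects the result, and the phenyl compound is the weaker inhibitor. Its true size cannot be read from this pair, because the step rests on a limit of the assay and gives only a minimum: the limit of > 30000 nM in this assay, at which 2 of the 4 values shown sit.

The swap also changes several things at once, since the leaving group has two rings and two nitrogen atoms, while phenyl has one ring and no nitrogen, so this pair cannot show which of these differences matters. The compounds shown leave open how a pyridinyl group, which keeps a single six-membered aromatic ring but includes one nitrogen, or an imidazol-1-yl group, which keeps only the five-membered ring with its two nitrogen atoms, would compare at this position.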